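Phenethyl for 2-phenylethynyl on the amide, two cores

A few compounds are considered here, and "the series" means these few. Any claim that something is new, unique, unknown or untested is made for them only; others in the source may bear on it.

Measured so far in a functional assay on NIH3T3 cells for agonist activity at Urotensin-2 receptor (Homo sapiens), with a stated time of 5 days; a lower number here means a smaller maximal response, a higher number a larger maximal response:
Compound 1 `Cc1ccc(C(CCN(C)C)NC(=O)C#Cc2ccccc2)cc1` gives 131%.
Compound 2 `Cc1ccc(C(CCN(C)C)NC(=O)CCc2ccccc2)cc1` gives 73%.
Compound 3 `CN(C)CCC(NC(=O)C#Cc1ccccc1)c1ccc2ccccc2c1` gives 115%.

Compound 1 and compound 2 share one core and differ in a single place: phenethyl in place of 2-phenylethynyl on a carbonyl carbon. This change gave a number 58 percentage points lower from compound 1 to compound 2 (beyond the scatter), a drop that is clearly beyond the scatter of the measurement. Compound 3 carries a second core; the difference between the two cores is not broken down here. In this assay compound 3 stands second highest of the three numbers, its step to compound 1 beyond the scatter and its step to compound 2 likewise beyond the scatter.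

Compound 4 `CN(C)CCC(NC(=O)CCc1ccccc1)c1ccc2ccccc2c1` has not yet been measured. It differs from compound 3 by phenethyl in place of 2-phenylethynyl on a carbonyl carbon, the same change seen between compound 1 and compound 2, at a place described in identical words for both pairs, so it counts as the same change and the series shows it twice in all.

From compound 3 to compound 4 a step of the same kind and of similar size is expected, a number 58 percentage points lower from compound 3 to compound 4 (beyond the scatter), because a number 58 percentage points lower from compound 1 to compound 2 (beyond the scatter) was large and beyond the scatter. Among the measured compounds shown here, since only one earlier instance exists, the width of the expectation is kept generous. For compound 4 in this assay the estimate is 57%, with a range from 35% to 85%.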

Compound 4, largest response reached (reported as efficacy), in percent of the reference or control that the assay uses: 107%
For compound 4 the middle estimate is 50 percentage points below the measured one; the whole stated range lies below it.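

Working notes on the cores: in this assay, phenethyl in place of 2-phenylethynyl on a carbonyl carbon gives a number 8 percentage points lower from compound 3 to compound 4 (within the scatter) on the core of compound 3, so this pair cannot be told apart on largest response. The change therefore does not carry over at a fixed size from the core of compound 1 to the core of compound 3, and the earlier step is a poor guide to the size of the step on the second core: the same change on two cores in this assay, a number 58 percentage points lower (beyond the scatter) from compound 1 to compound 2 and a number 8 percentage points lower (within the scatter) from compound 3 to compound 4, 50 percentage points apart, beyond the scatter of two such steps

With one matched pair on each core, this shows only that the outcome of the change differed on these two cores; it does not show which feature of the cores is responsible, nor how the change would behave on any third core.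

Still open, as far as these compounds go, is whether the same core dependence appears with a styryl group or a longer chain such as 3-phenylpropyl on the carbonyl carbon. Also open, from the compounds shown here alone, is whether it survives when dimethylamino is replaced by another amine such as pyrrolidine or morpholine, which would test whether the two cores continue to part ways with other groups on the amide.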